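A Methyl Added Beside the Retained Chloro Core

The source may hold more compounds than are shown below. What is called first, only, known or untested is meant among the compounds shown, and "the series" means these compounds.

Compound 1 `O=C(Nc1cc(C(F)(F)F)cc(C(F)(F)F)c1)c1cnc(Cl)nc1` holds the only measured number in an assay on Jurkat cells for activation of nuclear factor NF-kappa-B complex (Homo sapiens) (a lower number here means a stronger inhibitor, a higher number a weaker inhibitor), among these compounds: compound 1 gives 300 nM. The other two measured compounds stop at the limit of the assay. Compound 3 `O=C(Nc1cc(C(F)(F)F)cc(C(F)(F)F)c1)c1cnc(C(F)(F)F)nc1`, in this assay, gives > 10000 nM, which is a limit and not a number. Compound 2 `Cc1ncc(C(=O)Nc2cc(C(F)(F)F)cc(C(F)(F)F)c2)c(C(F)(F)F)n1`, carrying both a methyl and a trifluoromethyl on its core, gives > 10000 nM; > 10000 nM (2 entries) in this assay, a limit in each of its two entries. Among the compounds with values here, the single step that the numbers allow, an at least 33-fold higher number from compound 1 to compound 3 (1.52 log units; beyond the scatter), runs up to the limit of > 10000 nM in this assay, at which 1 of the 3 values shown sits.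

Compound 4 `Cc1nc(Cl)ncc1C(=O)Nc1cc(C(F)(F)F)cc(C(F)(F)F)c1` differs from compound 1 by methyl in place of hydrogen on an aromatic carbon. Within the data shown here, the chloro that compound 1 carries is kept in compound 4, so the large step seen in this assay from compound 1 to compound 3 does not bear on this change, and no measured pair shows a methyl entering in place of hydrogen on its own. With nothing to point either way, the expectation for compound 4 in this assay is a step within the scatter, a 1.3-fold higher number from compound 1 to compound 4 (0.12 log units; within the scatter). Compound 4 is therefore estimated at 400 nM, with a range from 100 nM to 2000 nM.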

Compound 4, half-maximal inhibitory concentration: 50 nM
Beside the measured number, compound 4's estimate is 8.0-fold (0.90 log units) above it; the whole stated range lies above it.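

Within the data shown here, the methyl entering on the aromatic carbon next to the ring nitrogen, ortho to a large group, gives the first step in this assay that leads to a stronger inhibitor, a 6.0-fold lower number from compound 1 to compound 4 (0.78 log units; beyond the scatter), with the chloro kept in place. This shows that the position can carry a substituent, and that a single added carbon on the core of compound 1 is enough to move the number beyond the scatter. Among these compounds, the only earlier step, an at least 33-fold higher number from compound 1 to compound 3 (1.52 log units; beyond the scatter), ran the other way and replaced the chloro, so the two steps concern different places on the core, and neither one predicts the other.

Going by these compounds, whether an ethyl or an amine at this position would lower the number further stays open, as does whether the methyl would have the same effect with a group other than the chloro on the core. The values shown offer no measured property that accounts for this step, and nothing in the available evidence bears on its cause.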